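Chalcone-type series: carbonyl-side aryl exchange toward compound 4

The source may report more compounds than this note shows. Statements on the series, on what has been measured and on what is new or still open speak of the compounds shown alone.

Measured compounds:
- compound 1 `COc1ccc(-c2cc(/C=C/C(=O)c3ccc(OC)c(OC)c3)[nH]n2)cc1`: 1400 nM in a functional assay on DU-145 cells (Homo sapiens) for inhibition, read by sulforhodamine B assay, with a stated time of 48 h; on this read-out higher numbers stand for weaker inhibition of growth and lower numbers for stronger inhibition of growth
- compound 2 `COc1cc(-c2cc(/C=C/C(=O)c3ccc(Cl)c(Cl)c3)[nH]n2)cc(OC)c1OC`: "not determined" (no result reported) in this assay
- compound 3 `COc1ccc(-c2cc(/C=C/C(=O)c3ccc(N)cc3)[nH]n2)cc1OC`: 3740 nM in this assay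

Compound 2 has no number in this assay; its place among the measured compounds cannot be stated. Compound 1 and compound 3 both carry values, and the gap between them is modest on the scale of this read-out.

Among the measured compounds shown here, compound 4 `COc1ccc(C(=O)/C=C/c2cc(-c3cc(OC)c(OC)c(OC)c3)n[nH]2)cc1OC` is the one compound still to be measured. It differs from compound 2 in a single place: 3,4-dimethoxyphenyl in place of 3,4-dichlorophenyl on a carbonyl carbon. For the measured compounds named here, no measured pair records this exchange, so the size and direction of the step from compound 2 to compound 4 cannot be read from the data; with the starting point itself unmeasured, no step in this assay is estimated at all.

What can be said rests on compound 1, which carries the same 3,4-dimethoxyphenyl on the carbonyl carbon and gives 1400 nM. Compound 4 is expected to land near that figure, estimated at 1000 nM, with a plausible range from 300 nM to 4000 nM.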

Compound 4, concentration for 50% growth inhibition: 550 nM
For compound 4 the middle estimate is 1.8-fold (0.26 log units) above the measured one; low and high end bracket the measured number.
By their numbers in this assay, from the lowest: compound 4; then compound 1; then compound 3.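

Among the compounds shown here, no step from compound 2 to compound 4 can be read, as compound 2 carries no number in this assay in these notes. No measured property bears on this result. The compounds shown leave open how exchanging 3,4-dichlorophenyl for 3,4-dimethoxyphenyl on a carbonyl carbon alters growth inhibition.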